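Allyl in place of propargyl on the methoxy analogue

A few compounds are considered here, and "the series" means these few. Any claim that something is new, unique, unknown or untested is made for them only; others in the source may bear on it.

For the measured compounds named here, compound 2 `C#CCNC(=O)/C(C)=C(\C)c1ccc(OC)cc1` gives 150 mg/kg in a toxicity assay on the whole organism (strain Icem-CET (SPF Caw)) for cytotoxicity, with Mus musculus as the target (on this read-out higher numbers stand for an effect only at larger amounts of compound and lower numbers for an effect already at smaller amounts), the lowest of the three numbers measured so far. Compound 3 `C#CCNC(=O)/C(C)=C(\C)c1ccc(Cl)cc1` gives 200 mg/kg, and a 1.3-fold higher number from compound 2 to compound 3 (0.12 log units; within the scatter). Compound 1 `C=CCNC(=O)/C(C)=C(\C)c1ccc(Br)cc1` gives 500 mg/kg, a gap from compound 2 that is beyond the scatter.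

Compound 4 `C=CCNC(=O)/C(C)=C(\C)c1ccc(OC)cc1` arises from compound 2 by vinyl in place of ethynyl on a saturated chain carbon bound to an amide-type nitrogen. Going by the values given here, no measured step varies the propargyl group alone. Among the compounds with values here, compound 1 is the only allyl amide, but it also carries bromo where compound 2 carries methoxy, so the pair differs in two places and shows only that the allyl-bromo compound 1 returns the highest number of the set while the propargyl compounds 2 and 3 sit lower. The halogen exchange seen in the step from compound 2 to compound 3 stayed within the scatter, which leaves open how much of the gap to compound 1 belongs to the allyl group.

Taking that gap as a loose pointer, a modest rise is expected, a 2.0-fold higher number from compound 2 to compound 4 (0.30 log units; within the scatter), which lies at the edge of the scatter. Compound 4 is accordingly estimated at 300 mg/kg in this assay, within a range from 150 mg/kg to 600 mg/kg.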

Compound 4, dose for half-maximal effect: 300 mg/kg
Compound 4: the middle estimate sits on the measured number at the digits printed, within the range that was stated.
By their numbers in this assay, from the lowest: compounds 2, 3, 4 and 1 (each within the scatter of the next, the first and the last beyond it).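

In this assay, for the compounds shown here, vinyl in place of ethynyl on a saturated chain carbon bound to an amide-type nitrogen gives a 2.0-fold higher number from compound 2 to compound 4 (0.30 log units; within the scatter), the first step that varies the propargyl group alone, and it places the propargyl to allyl change at the edge of the scatter without taking it beyond. With the allyl amide held constant, methoxy in place of bromo on an aromatic carbon gives a 1.7-fold lower number from compound 1 to compound 4 (0.22 log units; within the scatter), so the aromatic substituent has now been varied on both the propargyl and the allyl amide, and neither single exchange in these compounds leaves the scatter. Nothing at hand bears on why these numbers fall as they do.

From the compounds shown here alone, how this place in the molecule responds to a group that differs more from propargyl and allyl, such as a longer chain or a chain ending in an amine, remains open. Also open, going by these compounds, is whether a carboxylic acid on the aromatic carbon would give a step beyond the scatter on either amide.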